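Phenyl for Methyl on the Carbonyl of Compound 3

A few compounds are considered here, and "the series" means these few. Any claim that something is new, unique, unknown or untested is made for them only; others in the source may bear on it.

Measured compounds and their values:
- Compound 1, `COc1ccc2[nH]c(-c3ccccc3)c(C=C(C#N)C#N)c2c1`: 4200 nM
- Compound 2, `CCOC(=O)C(=Cc1c(-c2ccccc2)[nH]c2ccccc12)C(=O)OCC`: 7600 nM
- Compound 3, `CC(=O)/C(=C\c1c(-c2ccccc2)[nH]c2ccccc12)S(=O)(=O)c1ccccc1`: 2400 nM

All three compounds share a core carrying a double-bonded chain. In a functional assay on SF-295 cells (Homo sapiens) for inhibition, read by sulforhodamine B assay, with a stated time of 48 h (a higher number here means a weaker inhibitor of growth, a lower number a stronger inhibitor of growth), compound 3 gives 2400 nM, the lowest of the three numbers. Its gap to compound 1, which gives 4200 nM, lies within the scatter of repeated measurements, so the two cannot be placed in order. Its gap to compound 2, which gives 7600 nM, lies beyond the scatter, so compound 3 does stand at a lower number than compound 2.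

Compound 4, `O=C(/C(=C\c1c(-c2ccccc2)[nH]c2ccccc12)S(=O)(=O)c1ccccc1)c1ccccc1`, has not yet been measured. It differs from compound 3 in one place: phenyl in place of methyl on a carbonyl carbon. Among the measured compounds shown here, no two measured compounds differ from each other in only one place, so no single structural step has yet been measured in this assay, and the effect of this change has to be guessed without a direct precedent. For that reason the step from compound 3 to compound 4 is expected to be small, a 1.1-fold lower number from compound 3 to compound 4 (0.04 log units; within the scatter), in no clear direction and likely within the scatter. Compound 4 is therefore expected to give about 2200 nM in this assay, with a plausible range from 700 nM to 7000 nM.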

Compound 4, concentration for 50% growth inhibition: 3500 nM
Compound 4: the middle estimate sits 1.6-fold (0.20 log units) below what was measured; low and high end bracket the measured number.
By their numbers in this assay, from the lowest: compounds 3, 4, 1 and 2 (each within the scatter of the next, the first and the last beyond it).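

Among the compounds shown here, the change from acetyl to benzoyl gives, in this assay, a 1.5-fold higher number from compound 3 to compound 4 (0.16 log units; within the scatter), which is the first step in this set that changes only one place on the molecule. The numbers for the two compounds cannot be told apart, so on this carbonyl carbon, a whole aromatic phenyl ring in place of a lone methyl produces no change that this assay can resolve. No measured information is available to explain this result.

For the compounds shown here, this single step compares only two groups, so it cannot show whether the position would respond the same way to a different kind of group, such as an amine, a carboxylic acid or a longer alkyl chain, or to a phenyl ring that itself carries an amine. It also leaves open whether swapping methyl for phenyl would give a similarly small step on a compound with a different chain, since here it is seen only once, with the rest of the molecule held as in compound 3.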